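Swapping the methoxy for bromo on the aniline ring

The compounds below may be only part of what the source reports. "The series", "measured", "known", "first", "only" and "open" are said of these compounds alone.

The series rests on a shared sulfonamide-coumarin core. Compound 1 `COc1ccc(NS(=O)(=O)c2cc3cccc(Br)c3oc2=O)cc1` gives 16000 nM in a functional assay on BT-20 cells (Homo sapiens), with a stated time of 96 h; a higher number here means a weaker inhibitor of growth, a lower number a stronger inhibitor of growth. Compound 2 `CCOc1cccc2cc(S(=O)(=O)Nc3ccc(OC)cc3)c(=O)oc12` gives 52000 nM in this assay, and compound 3 `COc1ccc(NS(=O)(=O)c2cc3cc(Cl)ccc3oc2=O)cc1O` gives 65000 nM. Among these three numbers compound 2 stands second highest: its gap to compound 3 lies within the scatter, while a 3.3-fold higher number from compound 1 to compound 2 (0.51 log units; beyond the scatter) is the only step that reaches beyond it, and that step comes from an ethoxy in place of bromo on an aromatic carbon of the core.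

Compound 4 `CCOc1cccc2cc(S(=O)(=O)Nc3ccc(Br)cc3)c(=O)oc12` differs from compound 2 in another place: bromo in place of methoxy on an aromatic carbon of the six-membered aromatic ring of carbon only, para to a large group. Among the compounds with values here, no measured step bears on this change; every measured compound carries a 4-methoxyphenyl at that position, and the one step beyond the scatter concerns the core instead. With nothing to lean on, the expectation is a step of no clear direction, most likely within the scatter, so compound 4 is expected near compound 2, the estimated change being a 1.3-fold lower number from compound 2 to compound 4 (0.11 log units; within the scatter). Compound 4 is therefore estimated at 40000 nM, within the range 12000 nM to 130000 nM, in this assay.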

Compound 4, concentration for 50% growth inhibition: 64000 nM
Beside the measured number, compound 4's estimate is 1.6-fold (0.20 log units) below it; measured number inside the range.
By their numbers in this assay, from the lowest: compound 1; then compounds 2, 4 and 3 (each within the scatter of the next).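

Within the data shown here, the first measured change at this position, on an aromatic carbon para to a large group, gives a 1.2-fold higher number from compound 2 to compound 4 (0.09 log units; within the scatter) in this assay, so bromo and methoxy cannot be told apart here on the ethoxy-bearing core. Among these compounds, the earlier compounds all kept the methoxy at this position, so they could show only that a change on the core can move the number beyond the scatter; the 4-methoxyphenyl to 4-bromophenyl exchange, which also removes the oxygen of the methoxy, now shows a change on the aniline side that does not. Nothing measured here speaks to the reason for this result.

The compounds shown leave open whether the same exchange would also stay within the scatter on the core of compound 1, which carries bromo where compound 2 carries ethoxy. They also leave open how this position would respond to a group of a different kind, such as an amine, a carboxylic acid or a longer alkyl chain, in place of the methoxy or the bromo.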